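The source may report more compounds than this note shows. Statements on the series, on what has been measured and on what is new or still open speak of the compounds shown alone.

Measured so far in an assay on HL-60 cells for agonist activity at vitamin D3 receptor (Homo sapiens), read by microscopy, with a stated time of 96 h; on this read-out higher numbers stand for an effect only at larger amounts of compound and lower numbers for an effect already at smaller amounts:
compound 1 `CCOC(=O)CN(C)C(=O)c1ccc(C(CC)(CC)c2ccc(OCC(=O)C(C)(C)C)c(C)c2)n1CC` — > 50000 nM, a limit of the assay, not a number.
compound 2 `CCOC(=O)CN(C)C(=O)c1ccc(C(CC)(CC)c2ccc(OCC(O)C(C)(C)C)c(C)c2)n1CC` — 210 nM.
compound 3 `CC[C@@H](C)[C@H](NC(=O)c1ccc(C(CC)(CC)c2ccc(OCC(=O)C(C)(C)C)c(C)c2)n1CC)C(=O)O` — 10 nM.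

Of compound 1 only the limit is known (the limit of > 50000 nM in this assay, at which 1 of the 3 values shown sits). Compound 2 differs from compound 1 by 1-hydroxy-2,2-dimethylpropyl in place of (tert-butyl)carbonyl on a saturated chain carbon bound to an oxygen on an aromatic ring; the step is an at least 230-fold lower number from compound 1 to compound 2 (2.37 log units; beyond the scatter). Compound 3 differs from compound 1 at the other end of the shared core by (1-carboxy-2-methylbutyl)amino in place of ((ethoxycarbonyl)methyl)(methyl)amino on a carbonyl carbon; the step is an at least 5000-fold lower number from compound 1 to compound 3 (3.69 log units; beyond the scatter). Compound 3 stands lowest of the two numbers given, the nearest being compound 2.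

Compound 4 `CC[C@@H](C)[C@H](NC(=O)c1ccc(C(CC)(CC)c2ccc(OCC(O)C(C)(C)C)c(C)c2)n1CC)C(=O)O` is not yet measured. It differs from compound 3 by 1-hydroxy-2,2-dimethylpropyl in place of (tert-butyl)carbonyl on a saturated chain carbon bound to an oxygen on an aromatic ring, the same change at the same place as from compound 1 to compound 2. Since the earlier step of an at least 230-fold lower number from compound 1 to compound 2 (2.37 log units; beyond the scatter) starts from a limit, only its least size is known, and compound 3 already sits low, so a smaller step is expected: a 3.3-fold lower number from compound 3 to compound 4 (0.52 log units; beyond the scatter). Compound 4 is estimated at 3 nM, between 0.5 nM and 20 nM.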

Compound 4, half-maximal effective concentration: 2.3 nM
Beside the measured number, compound 4's estimate is 1.3-fold (0.12 log units) above it, within the range that was stated.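

In this assay, 1-hydroxy-2,2-dimethylpropyl in place of (tert-butyl)carbonyl again lowers the number on a second core, giving a 4.3-fold lower number from compound 3 to compound 4 (0.64 log units; beyond the scatter), but the step is smaller than on the first core: the same change on two cores in this assay, an at least 230-fold lower number (2.37 log units; beyond the scatter) from compound 1 to compound 2 and a 4.3-fold lower number (0.64 log units; beyond the scatter) from compound 3 to compound 4, at least 54-fold (1.73 log units) apart, beyond the scatter of two such steps. (1-Carboxy-2-methylbutyl)amino in place of ((ethoxycarbonyl)methyl)(methyl)amino likewise gives a 91-fold lower number from compound 2 to compound 4 (1.96 log units; beyond the scatter), again a smaller step: the same change on two cores in this assay, an at least 5000-fold lower number (3.69 log units; beyond the scatter) from compound 1 to compound 3 and a 91-fold lower number (1.96 log units; beyond the scatter) from compound 2 to compound 4, at least 54-fold (1.73 log units) apart, beyond the scatter of two such steps. Direction therefore carries over between these two cores and size does not, but compound 1 is a limit of the assay, not a number, so the full size of either earlier step stays unknown: the limit of > 50000 nM in this assay, at which 1 of the 4 values shown sits.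

Open, going by these compounds, is whether the gain at the carbonyl carbon follows the carboxylic acid or the branched chain. A (carboxymethyl)(methyl)amino group at that place would separate the two.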